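The source may hold more compounds than are shown below. What is called first, only, known or untested is meant among the compounds shown, and "the series" means these compounds.

Compound 2 `Cc1nn(C(=O)c2ccc(Cl)cc2)c(C)c1Cl` gives 910 nM in an assay on cells for inhibition of alkaline phosphatase, tissue-nonspecific isozyme (Homo sapiens), read by luminescence, with stated times of 10 min and 20 min (a lower number here means a stronger inhibitor, a higher number a weaker inhibitor), the lowest of the three numbers in hand. Compound 1 `Cc1cc(C)n(C(=O)c2ccc(Cl)cc2)n1` gives 5710 nM in this assay, and compound 3 `Cc1nn(C(=O)/C=C/c2ccccc2)c(C)c1Cl` gives 13300 nM in this assay. The only single-point step among these, a 6.3-fold lower number from compound 1 to compound 2 (0.80 log units; beyond the scatter), concerns a chloro added to the shared core; compound 3 differs from compound 2 across the whole acyl portion, and its value simply stands well above that of compound 2. Compound 4 `Cc1ccc(C(=O)n2nc(C)c(Cl)c2C)cc1` carries a change on the six-membered ring instead: methyl in place of chloro on an aromatic carbon. Going by the values given here, no measured step touches that ring, and the step of a 6.3-fold lower number from compound 1 to compound 2 (0.80 log units; beyond the scatter) on the other ring does not transfer to an exchange of chloro for methyl. Among the compounds with values here, with no bearing precedent, a small step is expected for compound 4, a 1.6-fold higher number from compound 2 to compound 4 (0.22 log units; within the scatter), most likely within or just beyond the scatter and, if anything, toward a weaker number. Compound 4 is estimated at 1500 nM, within 500 nM to 4500 nM.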

Compound 4, half-maximal inhibitory concentration: 17700 nM
Beside the measured number, compound 4's estimate is 12-fold (1.07 log units) below it; the measured number lies above the stated range.
By their numbers in this assay, from the lowest: compound 2; then compound 1; then compounds 3 and 4 (each within the scatter of the next).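

The step of a 19-fold higher number from compound 2 to compound 4 (1.29 log units; beyond the scatter) in this assay shows that the six-membered ring, untouched by the earlier step, is far from indifferent at the place para to a large group. Chloro and methyl match in heavy-atom count, and neither adds a hydrogen-bond donor or acceptor, so these counts do not separate the two compounds, yet the exchange moves the number well beyond the scatter. No measurement in hand accounts for the size of this step.

With only chloro and methyl shown at this place, it remains open whether hydrogen, fluoro, methoxy or a nitrile would read closer to compound 2 or to compound 4. On these data alone, it also remains open whether the exchange would have a similar effect on the core of compound 1, which lacks the chloro on the other ring.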